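This account rests on a few compounds, and the source may have more. Where it says the series, first, only, none or still open, it means among the compounds named here.

Going by the values given here, compound 2 `N#Cc1cnc(NCc2cnccc2C(F)(F)F)cc1N[C@H]1CC[C@@H](C(N)=O)CC1` gives 400 nM in an assay on isolated protein for inhibition of protein kinase C delta type (Homo sapiens), read by TR-FRET, with a stated time of 2 h (on this read-out lower numbers stand for stronger inhibition and higher numbers for weaker inhibition), the lower of the two numbers so far; compound 1 `CO[C@H]1CC[C@@H](CNc2cc(NCc3cnccc3C(F)(F)F)ncc2C#N)CC1` gives 5000 nM. Among the compounds with values here, the one measured step, a 13-fold lower number from compound 1 to compound 2 (1.10 log units; beyond the scatter), is the only guide for compound 3 `CC1(C)C[C@@H](Nc2cc(NCc3cnccc3C(F)(F)F)ncc2C#N)CC[C@H]1O`, which carries 4-hydroxy-3,3-dimethylcyclohexyl in place of 4-carbamoylcyclohexyl on a nitrogen on an aromatic ring. That step exchanged the whole substituent on the same nitrogen, while here the ring stays directly attached and the donor and acceptor count is kept, so a change of much smaller size than the measured step is expected, in either direction, likely within the scatter, as a 1.5-fold higher number from compound 2 to compound 3 (0.18 log units; within the scatter). Compound 3 is estimated at 600 nM, between 200 nM and 2000 nM.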

Compound 3, half-maximal inhibitory concentration: 2400 nM
For compound 3 the middle estimate is 4.0-fold (0.60 log units) below the measured one; measured number outside the range, above it.
By their numbers in this assay, from the lowest: compound 2; then compound 3; then compound 1.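

On this nitrogen, a directly attached ring with matching donor and acceptor counts does not by itself preserve the number in this assay, as 4-hydroxy-3,3-dimethylcyclohexyl in place of 4-carbamoylcyclohexyl gives a 6.0-fold higher number from compound 2 to compound 3 (0.78 log units; beyond the scatter). The same group still retains part of the earlier gain over (4-methoxycyclohexyl)methyl, with a 2.1-fold lower number from compound 1 to compound 3 (0.32 log units; beyond the scatter). Nothing measured here gives a reason for either step.

Still open, going by these compounds, is whether the change in this assay follows from losing the carbamoyl group, from replacing it with hydroxy, or from adding the 3,3-dimethyl groups. Also open, on these data alone, is how 4-aminocyclohexyl or 4-carboxycyclohexyl would read on this nitrogen.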